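A few compounds are considered here, and "the series" means these few. Any claim that something is new, unique, unknown or untested is made for them only; others in the source may bear on it.

Going by the values given here, in a functional assay on the whole organism (Hindlimb, strain albino) with Mus musculus as the target, in the maximal electroshock model, with a stated time of 0.5 h (on this read-out lower numbers stand for an effect already at smaller amounts and higher numbers for an effect only at larger amounts of compound), compound 1 (`COc1ccc(/C=C/C(=O)Nc2nc3ccc([N+](=O)[O-])cc3s2)cc1`) gives 315 umol/kg and compound 2 (`O=C(/C=C/OC1=CC=C1)Nc1nc2ccc([N+](=O)[O-])cc2s1`) gives 597 umol/kg so compound 2 stands within the scatter of the only other measured number. Compound 3 (`O=C(/C=C/c1ccccc1)Nc1nc2ccc([N+](=O)[O-])cc2s1`) differs from compound 2 by one group (a group of 6 heavy atoms (6 carbon; one six-membered aromatic ring of carbon only) in place of a group of 5 heavy atoms (4 carbon, 1 oxygen; one four-membered non-aromatic ring of carbon only), on a double-bonded chain carbon bound to a double-bonded chain carbon). Among the compounds with values here, the one measured step at that place (a 1.9-fold higher number from compound 1 to compound 2 (0.28 log units; within the scatter)) lies within the scatter and is the only guide. Compound 3 keeps a six-membered aromatic ring as compound 1 (315 umol/kg) does, so the expectation leans toward that number. No step beyond the scatter is expected in this assay and the estimated step (a 1.5-fold lower number from compound 2 to compound 3 (0.17 log units; within the scatter)) stays small. For compound 3 the estimate is 400 umol/kg (expected range 180 umol/kg to 850 umol/kg).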

Compound 3, dose for half-maximal effect: 485 umol/kg
Beside the measured number, compound 3's estimate is 1.2-fold (0.08 log units) below it; measured number inside the range.
By their numbers in this assay, from the lowest: compounds 1, 3 and 2 (each within the scatter of the next).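

Replacing the four-membered carbon ring group with phenyl on the double-bonded chain carbon gives a 1.2-fold lower number from compound 2 to compound 3 (0.09 log units; within the scatter). Removing the methoxy, with hydrogen in its place on an aromatic carbon, gives a 1.5-fold higher number from compound 1 to compound 3 (0.19 log units; within the scatter). Neither change separates the compounds in this assay, so this position has so far tolerated all three groups without a step beyond the scatter, and no measured evidence bears on these results.

Still open, on these data alone, is whether an amine or a carboxylic acid on the phenyl ring would give a step beyond the scatter. The same applies to a longer chain in place of phenyl.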